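Adding Fluoro to the 3-Methoxyphenyl End of Compound 3

A few compounds are considered here, and "the series" means these few. Any claim that something is new, unique, unknown or untested is made for them only; others in the source may bear on it.

Compound 1, `COc1ccc(C(=O)c2cc(OC)c(OC)c(OC)c2)cc1N`, gives 50 nM in a functional assay on HT-29 cells (Homo sapiens) for cytotoxicity, read by MTT assay, with a stated time of 72 h; a lower number here means a stronger inhibitor, a higher number a weaker inhibitor.
Compound 2, `COc1ccc(/C=C/C(=O)Nc2cc(C(=O)c3cc(OC)c(OC)c(OC)c3)ccc2OC)cc1`, gives 5010 nM in this assay.
Compound 3, `COc1cccc(/C=C/C(=O)Nc2cc(C(=O)c3cc(OC)c(OC)c(OC)c3)ccc2OC)c1`, gives 1900 nM in this assay.

Compound 3 stands second highest of the three numbers; its nearest neighbour is compound 2, seen in a 2.6-fold lower number from compound 2 to compound 3 (0.42 log units; beyond the scatter), and compound 1 lies far below it. Compound 4, `COc1cc(/C=C/C(=O)Nc2cc(C(=O)c3cc(OC)c(OC)c(OC)c3)ccc2OC)ccc1F`, differs from compound 3 by fluoro in place of hydrogen on an aromatic carbon. Among the measured compounds shown here, no measured step introduces a fluoro group, so nothing bears directly on this change. The one step among these compounds, a 2.6-fold lower number from compound 2 to compound 3 (0.42 log units; beyond the scatter), came from moving a methoxy group and was modest. The fluoro addition is therefore expected to give no step beyond the scatter in this assay, as a 1.1-fold lower number from compound 3 to compound 4 (0.02 log units; within the scatter). Compound 4 is estimated at 1800 nM, within 700 nM to 4500 nM.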

Compound 4, half-maximal inhibitory concentration: 7700 nM
Compound 4: middle estimate off by 4.3-fold (0.63 log units), on the low side; the measured number lies above the stated range.
By their numbers in this assay, from the lowest: compound 1; then compound 3; then compounds 2 and 4 (each within the scatter of the next).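

On the 3-methoxyphenyl end, fluoro para to a large group and ortho to the methoxy group is not a silent change: in this assay it gives a 4.1-fold higher number from compound 3 to compound 4 (0.61 log units; beyond the scatter) and so costs more than moving the methoxy group gained. Against compound 2, the 4-fluoro-3-methoxyphenyl end gives a 1.5-fold higher number from compound 2 to compound 4 (0.19 log units; within the scatter), so the added fluoro cancels the earlier gain. Nothing available here explains this step. Still open, going by these compounds, is whether chloro, hydroxy or an amine at the same place would raise the number as fluoro does, or whether this rise is particular to fluoro.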